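The source may report more compounds than this note shows. Statements on the series, on what has been measured and on what is new or still open speak of the compounds shown alone.

Compound 1 `COc1ccc2c(c1)[n+]([O-])c(C#N)c(-c1ccc(F)cc1)[n+]2[O-]` and compound 2 `COc1ccc2c(c1)[n+]([O-])c(C#N)c(-c1ccc(Cl)cc1)[n+]2[O-]` share one core, while compound 3 `Cc1ccc(-c2c(C#N)[n+]([O-])c3cc(F)ccc3[n+]2[O-])cc1` and compound 4 `Cc1ccc(-c2c(C#N)[n+]([O-])c3cc(Cl)ccc3[n+]2[O-])cc1` share another; the difference between the two cores is not broken down here. In a physicochemical assay for lipophilicity, measured as octanol-water partition (on this read-out higher numbers stand for higher lipophilicity and lower numbers for lower lipophilicity), compound 1 gives 1.97 and compound 2 gives 2.09. Their difference is chloro in place of fluoro on an aromatic carbon, and the resulting step was a number 0.12 log units higher from compound 1 to compound 2 (within the scatter). In this assay compound 3 gives 2.48, the highest of the three measured numbers. Compound 4 differs from compound 3 by chloro in place of fluoro on an aromatic carbon. This is the same kind of change, but its surroundings differ: in compound 2 the chloro sits on a six-membered aromatic ring of carbon only, para to a large group, whereas in compound 4 the ring is part of a fused or bridged system of two rings, meta to a fused ring and para to a fused ring. The expected step is a number 0.27 log units higher from compound 3 to compound 4 (within the scatter) in this assay, because the earlier change gave a number 0.12 log units higher from compound 1 to compound 2 (within the scatter) and only a small rise is therefore expected here. Compound 4 is therefore estimated at 2.75 in this assay, expected to lie between 2.45 and 3.05.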

Compound 4, partition coefficient: 2.6
The estimate for compound 4 lay 0.15 log units above the measured number; the range from low to high includes it.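

In this assay, chloro in place of fluoro on an aromatic carbon gave a number 0.12 log units higher from compound 3 to compound 4 (within the scatter), and on the other core it gave a number 0.12 log units higher from compound 1 to compound 2 (within the scatter), so the two steps have the same size even though the place differs, with the ring of compound 4 part of a fused or bridged system of two rings. Each step lies within the scatter, so this shows a consistent small difference across two pairs at most and does not establish a real effect of the change on either core. Nothing measured here bears on the reason for the match.

As far as these compounds go, whether the same agreement holds for bromo on these cores remains open. From the compounds shown here alone, how an amine or a carboxylic acid on that aromatic carbon would compare with fluoro is also open.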